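Swapping thiophen-3-yl for 4-chlorophenyl at one ring carbon

This account rests on a few compounds, and the source may have more. Where it says the series, first, only, none or still open, it means among the compounds named here.

Of the compounds shown here, two with a shared core have been measured in a functional assay on CHO cells for agonist activity at Free fatty acid receptor 1 (Homo sapiens), read by FLIPR and calcium flux, tested at 100 nM; on this read-out higher numbers stand for a stronger effect at the one concentration tested and lower numbers for a weaker effect. Compound 1 `Cc1cc(COc2ccc3c(c2)OCC3CC(=O)O)nn1-c1ccccc1` gives 0.98%, which is essentially no response. Compound 2 `Cc1nc(-c2ccsc2)sc1COc1ccc2c(c1)OCC2CC(=O)O` gives 56.5%, the higher of the two numbers; compound 1 sits far below it, a gap well beyond the usual scatter, so compound 2 is clearly the stronger of the pair in this assay.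

Compound 3 `Cc1nc(-c2ccc(Cl)cc2)sc1COc1ccc2c(c1)OCC2CC(=O)O` has not yet been measured. It differs from compound 2 in a single place: 4-chlorophenyl in place of thiophen-3-yl on an aromatic carbon. Among the compounds with values here, no measured pair shows this kind of exchange, so nothing measured says how large the resulting step in this assay should be. Both the leaving and the entering group are flat aromatic rings of similar size, so the change is expected to be modest, with a small downward lean but probably not beyond the scatter: the step from compound 2 to compound 3 is expected to be a number 6.5 percentage points lower from compound 2 to compound 3 (within the scatter). Compound 3 is therefore estimated at 50%, within a range from 20% to 80%, because compound 2 gives 56.5% and most of that response is expected to be kept.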

Compound 3, a percentage reported as activity, at one concentration (the size of the read-out at that concentration, not a potency): 53.4%
Estimate against measurement, compound 3: 3.4 percentage points below, and the stated range covers the measured number.
By their numbers in this assay, from the lowest: compound 1; then compounds 3 and 2 (each within the scatter of the next).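

In this assay, the carbon of the five-membered aromatic ring with 1 nitrogen and 1 sulfur, next to the ring nitrogen and next to the ring sulfur, takes a change of aromatic group with a step of a number 3.1 percentage points lower from compound 2 to compound 3 (within the scatter). Within the data shown here, this is the first measured exchange at this place, and it shows that the response at the one concentration tested holds up even though the exchange alters several things at once: a five-membered aromatic ring with a sulfur gives way to a six-membered aromatic ring of carbon only, a chlorine enters, and the group grows from 5 to 7 heavy atoms. Nothing available explains why thiophen-3-yl and 4-chlorophenyl read alike here.

The two groups are both aromatic rings, so the compounds shown leave open whether an aromatic ring is needed at this place at all, something a cyclohexyl ring or an amine such as morpholine could test. They also leave open what the chlorine contributes, since a plain phenyl at this place would separate the chlorine from the change of ring.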